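Bromo for hydroxy in a small set of three

A few compounds are considered here, and "the series" means these few. Any claim that something is new, unique, unknown or untested is made for them only; others in the source may bear on it.

Measured in a functional assay on MV4-11 cells (Homo sapiens) for antiproliferative activity, with a stated time of 48 h (on this read-out lower numbers stand for stronger inhibition and higher numbers for weaker inhibition), so far:
compound 1 (`CCCNNC(=O)c1ccc(CNC(=O)c2ccc3ccncc3c2)cc1`) gives 74 nM
compound 2 (`CCCNNC(=O)c1ccc(CNC(=O)c2cc3cc(O)ccc3o2)cc1`) gives 40 nM
compound 3 (`CCCNNC(=O)c1ccc(CNC(=O)c2cc3cc(OC)ccc3[nH]2)cc1`) gives 37.5 nM

Compound 2 at 40 nM stands within the usual scatter of both others, compound 3 at 37.5 nM and compound 1 at 74 nM in the same test, so these numbers cannot separate it from either one.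

Among the measured compounds shown here, compound 4 (`CCCNNC(=O)c1ccc(CNC(=O)c2cc3cc(Br)ccc3o2)cc1`) has no measurement yet. Compared with compound 2, the change is bromo in place of hydroxy on an aromatic carbon in words, bromo in place of hydroxy on an aromatic carbon, on a six-membered aromatic ring of carbon only.

For the measured compounds named here, no two measured compounds differ in one place alone, so the data hold no direct example of this swap. Going by the values given here, the only guide is indirect: the measured compounds differ in structure, yet compound 1 at 74 nM and compound 3 at 37.5 nM remain within the scatter of each other. No step beyond the scatter is therefore expected in this assay, in either direction. The estimated step is a 1.3-fold higher number from compound 2 to compound 4 (0.10 log units; within the scatter) in size, which is a small one. For compound 4 the estimated value is 50 nM with an expected range from 20 nM to 125 nM in this test.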

Compound 4, half-maximal inhibitory concentration: 159 nM
The estimate for compound 4 lay 3.2-fold (0.50 log units) below the measured number; measured number outside the range, above it.
By their numbers in this assay, from the lowest: compounds 3, 2 and 1 (each within the scatter of the next); then compound 4.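

In this assay, among the compounds shown here, bromo in place of hydroxy gives a 4.0-fold higher number from compound 2 to compound 4 (0.60 log units; beyond the scatter), and this is the first pair in the set that differs in one place alone. The step lies beyond the usual scatter, so the earlier impression of a flat set does not extend to this spot on the six-membered aromatic ring: here a higher number means weaker inhibition, and exchanging one heavy atom for another is enough to produce it. The hydroxy brings one hydrogen-bond donor and one hydrogen-bond acceptor while the bromo brings neither, but that is only a count, and nothing measured here explains the weaker result.

A single pair cannot show whether losing the hydroxy or gaining the bromo matters more, since both happen in the same swap. As far as these compounds go, an amine or a carboxylic acid at this same place on the core of compound 2 would help separate the two, and whether the same swap would give a similar step on the core of compound 3 remains open.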